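Working notes: 3,5-dimethyl-1H-1,2,4-triazol-1-yl in place of 4-methylpiperazin-1-yl

A few compounds are considered here, and "the series" means these few. Any claim that something is new, unique, unknown or untested is made for them only; others in the source may bear on it.

In a functional assay on HUVEC cells (Homo sapiens), read by scintillation counting and thymidine incorporation, with a stated time of 24 h (a lower number here means a stronger inhibitor, a higher number a weaker inhibitor), compound 1 `CCC(C)n1ncn(-c2ccc(N3CCN(c4ccc(OC[C@@H]5CO[C@@](CN(C)C)(c6ccc(Cl)cc6Cl)O5)cc4)CC3)cc2)c1=O` gives 1400 nM and compound 2 `CCC(C)n1ncn(-c2ccc(N3CCN(c4ccc(OC[C@@H]5CO[C@@](CN6CCN(C)CC6)(c6ccc(Cl)cc6Cl)O5)cc4)CC3)cc2)c1=O` gives 396 nM. Compound 2 therefore holds the lower of the two numbers and is the stronger inhibitor of this pair.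

Compound 3 `CCC(C)n1ncn(-c2ccc(N3CCN(c4ccc(OC[C@@H]5CO[C@@](Cn6nc(C)nc6C)(c6ccc(Cl)cc6Cl)O5)cc4)CC3)cc2)c1=O` keeps the core of compound 2 and carries 3,5-dimethyl-1H-1,2,4-triazol-1-yl in place of 4-methylpiperazin-1-yl on a saturated chain carbon bound to a saturated ring carbon.

Going by the values given here, only one measured step bears on this change, as it falls at the same place: a 3.5-fold lower number from compound 1 to compound 2 (0.55 log units; beyond the scatter). This step is modest but lies beyond the scatter. It exchanges one group for another at that carbon, but neither group has a five-membered aromatic ring, so the data give no firm direction for compound 3. A step no larger than that modest one is expected in this assay, with a slight lean towards a higher number. The expected change is a 1.4-fold higher number from compound 2 to compound 3 (0.14 log units; within the scatter). For compound 3, the estimate is 550 nM, with an expected range of 170 nM to 1500 nM.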

Compound 3, half-maximal inhibitory concentration: 221 nM
The estimate for compound 3 lay 2.5-fold (0.40 log units) above the measured number; the range from low to high includes it.
By their numbers in this assay, from the lowest: compounds 3 and 2 (each within the scatter of the next); then compound 1.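

In this assay, 3,5-dimethyl-1H-1,2,4-triazol-1-yl on a saturated chain carbon bound to a saturated ring carbon cannot be separated from 4-methylpiperazin-1-yl (a 1.8-fold lower number from compound 2 to compound 3 (0.25 log units; within the scatter)), so a five-membered aromatic ring serves at this place as well as a six-membered non-aromatic ring. Measured against dimethylamino, the triazole gives a step beyond the scatter (a 6.3-fold lower number from compound 1 to compound 3 (0.80 log units; beyond the scatter)), which leaves dimethylamino apart from both ring-bearing groups, and none of the three compounds goes against this reading. No supporting data are available to explain why the two ring-bearing groups read alike or why dimethylamino differs from them.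

The compounds shown leave open whether the two methyl groups on the triazole contribute, and how an unsubstituted 1H-1,2,4-triazol-1-yl or an imidazol-1-yl would read at this carbon. Also open, as far as these compounds go, is whether a morpholin-4-yl, with its ring oxygen in place of the methyl-bearing ring nitrogen of 4-methylpiperazin-1-yl, would stay level with compound 2 and compound 3 or fall back towards compound 1.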